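Aryl swap at the amide end: cytotoxicity notes

The source may report more compounds than this note shows. Statements on the series, on what has been measured and on what is new or still open speak of the compounds shown alone.

Measured compounds:
compound 1 `CC(C)N(Cc1cccc(OCCCCCC(=O)O)c1)C(=O)c1ccc(-c2cccc3ccccc23)cc1` with < 1.3 nM
compound 2 `CC(C)N(Cc1cccc(OCCCCCC(=O)O)c1)C(=O)c1ccc(-c2ccc3cc[nH]c3c2)cc1` with > 26000 nM
compound 3 `CC(C)N(Cc1cccc(OCCCCCC(=O)O)c1)C(=O)c1ccc(-c2cccc(F)c2)cc1` not yet measured

In an ADME assay on BJ cells (Homo sapiens) for cytotoxicity, read by CellTiter-Glo and resazurin assay, with a stated time of 72 h (a lower number here means that less compound is needed, a higher number that more compound is needed for the effect), compound 1 gives < 1.3 nM, which is a limit of the assay (the limit of < 1.3 nM in this assay, at which 1 of the 2 values shown sits). Compound 2 gives > 26000 nM, also a limit (the limit of > 26000 nM in this assay, at which 1 of the 2 values shown sits). On these data alone, compound 2 therefore stands at the high end of the two readings, both of which are limits, so its true value is unknown. Within the data shown here, the one measured step, an at least 20000-fold higher number from compound 1 to compound 2 (4.30 log units; beyond the scatter), shows how strongly the aryl group at this position can move the read-out.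

Compound 3 carries 3-fluorophenyl in place of 1H-indol-6-yl on an aromatic carbon. Among the measured compounds shown here, no measured step covers this change; the only precedent swaps one bicyclic group for another. A partial move back toward compound 1 is expected, with wide uncertainty, giving an at least 5.2-fold lower number from compound 2 to compound 3 (0.71 log units; beyond the scatter). Compound 3 is estimated at 5000 nM, with a range from 300 nM to 26000 nM.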

Compound 3, half-maximal effective concentration: > 26000 nM
Compound 3: a limit, no number; the forecaster's own chance of this, stated with the estimate: 40%; at least 5.2-fold (0.71 log units) between middle value and limit.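

In this assay, on these data alone, compound 3 gives > 26000 nM, a limit of the assay, so its true value is unknown. Among these compounds, the change from naphthalen-1-yl to 3-fluorophenyl gives an at least 20000-fold higher number from compound 1 to compound 3 (4.30 log units; beyond the scatter), a second large step beside the one to 1H-indol-6-yl, which leaves naphthalen-1-yl as the only group of the three at the low limit. Compound 2 and compound 3 sit at the same limit, so the step between them cannot be read and 3-fluorophenyl cannot be ranked against 1H-indol-6-yl: the limit of > 26000 nM in this assay, at which 2 of the 3 values shown sit.

As far as these compounds go, with all three readings at limits, the real size of each step remains unknown. Open, from the compounds shown here alone, is where a naphthalen-2-yl group or an unsubstituted phenyl would fall, and whether either would stay at the low limit or move to the high one.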